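This account rests on a few compounds, and the source may have more. Where it says the series, first, only, none or still open, it means among the compounds named here.

Series so far, in a functional assay on SW620/5-FU cells (Homo sapiens) for cytotoxicity, read by MTT assay, with a stated time of 48 h, in the presence of a further agent that is not named here; on this read-out higher numbers stand for an effect only at larger amounts of compound and lower numbers for an effect already at smaller amounts:
- compound 1 `Cc1nn(C)c2nc(NNC(=O)Nc3cc(Cl)nc(Cl)c3)cc(C3CCCCC3)c12`: 22000 nM
- compound 2 `Cc1nn(C)c2nc(NNC(=O)Nc3cc(Cl)nc(Cl)c3)cc(-c3ccccc3)c12`: 22900 nM

Among the measured compounds shown here, compound 2, at 22900 nM, lies within the scatter of compound 1, its only measured neighbour, so the two cannot be ranked on these numbers. Both need concentrations in the same range for an effect in this assay.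

The next compound is compound 3 `Cc1nn(C)c2nc(NNC(=O)Nc3cc(Cl)nc(Cl)c3)cc(-c3ccc(Cl)s3)c12`, which keeps the shared core and carries 5-chlorothiophen-2-yl in place of phenyl on an aromatic carbon.

For the measured compounds named here, the one measured step that bears on this is a 1.0-fold higher number from compound 1 to compound 2 (0.02 log units; within the scatter). That swap also exchanges the group on this aromatic carbon, and it shows no change beyond the scatter. Going by the values given here, no measured compound carries 5-chlorothiophen-2-yl, so the evidence is indirect and rests on a single pair.

No step beyond the scatter is therefore expected in this assay, and the estimate is a 1.1-fold lower number from compound 2 to compound 3 (0.06 log units; within the scatter). Compound 3 is expected at 20000 nM, with an estimated range of 9000 nM to 42000 nM.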

Compound 3, half-maximal effective concentration: 29400 nM
Estimate against measurement, compound 3: 1.5-fold (0.17 log units) below, within the range that was stated.
By their numbers in this assay, from the lowest: compounds 1, 2 and 3 (each within the scatter of the next).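

At this aromatic carbon, opposite the ring nitrogen, the series now covers a five-membered aromatic ring with one hetero atom as well as the two carbon-only rings. In this assay, the change from phenyl to 5-chlorothiophen-2-yl gives a 1.3-fold higher number from compound 2 to compound 3 (0.11 log units; within the scatter), and the change from cyclohexyl to the same group gives a 1.3-fold higher number from compound 1 to compound 3 (0.13 log units; within the scatter). Compounds 1, 2 and 3 therefore cannot be ranked on this read-out, so the position has so far tolerated sulfur, chlorine and a hydrogen-bond acceptor in the entering group with no step beyond the scatter, and no accompanying measurement offers an explanation for this.

From the compounds shown here alone, all three groups at this position are rings, so it remains open whether an open-chain group such as n-butyl, an amine such as dimethylamino, or a carboxylic acid would produce a step beyond the scatter. The shared core is also constant across these compounds, which leaves open whether a change elsewhere, such as replacing the two chlorines with methyl groups, would move the number more than any change at this position has.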